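This account rests on a few compounds, and the source may have more. Where it says the series, first, only, none or still open, it means among the compounds named here.

Of the compounds shown here, two built on a shared core have been measured in a functional assay on B16-F10 cells (Mus musculus) for inhibition, read by MTT assay, with a stated time of 72 h; a higher number here means a weaker inhibitor of growth, a lower number a stronger inhibitor of growth. Compound 1 `CCOC(=O)c1ccc2[nH]c(-c3ccc(Cl)cc3)c(Oc3ccc(Cl)cc3)c2c1` gives 20000 nM in this assay. Compound 2 `CCOC(=O)C1CCN(C(=S)Sc2c(-c3ccc(Br)cc3)[nH]c3ccc(Cl)cc23)CC1` gives 21000 nM in this assay, and the two numbers lie within the usual scatter of each other, so neither compound stands apart. Compound 3 `COc1ccc2[nH]c(-c3ccc(Cl)cc3)c(Oc3ccc(Cl)cc3)c2c1` has not yet been measured. It differs from compound 1 in one place: methoxy in place of ethoxycarbonyl on an aromatic carbon. Among the measured compounds shown here, no pair of measured compounds differs only in this way, so nothing measured shows what this change does to growth inhibition. With only the two numbers of compound 1 and compound 2 to lean on, the change is expected to bring a step of no change at the digits printed from compound 1 to compound 3 (within the scatter), none beyond the scatter. Compound 3 is therefore estimated to give about 20000 nM in this assay, within a range from 6000 nM to 65000 nM.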

Compound 3, concentration for 50% growth inhibition: 31000 nM
Compound 3: the middle estimate sits 1.6-fold (0.19 log units) below what was measured; the measured number falls inside the stated range.
By their numbers in this assay, from the lowest: compounds 1, 2 and 3 (each within the scatter of the next).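

Among the compounds shown here, putting methoxy in place of ethoxycarbonyl on this aromatic carbon in this assay gives a 1.6-fold higher number from compound 1 to compound 3 (0.19 log units; within the scatter) and so offers the first direct reading of a change at this position. Within this single pair, the number shows no clear response even though the entering group has fewer heavy atoms and lacks the double bond of the group that leaves. Nothing at hand explains this result.

Two groups at one position are too few to show how far this tolerance extends. As far as these compounds go, a carboxylic acid, an amine or a longer chain on this same aromatic carbon could still shift growth inhibition beyond the scatter, and whether any group here can do so remains open.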